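Replacing a carbamate side chain with an ethyl ester

A few compounds are considered here, and "the series" means these few. Any claim that something is new, unique, unknown or untested is made for them only; others in the source may bear on it.

Measured so far in a functional assay on SK-OV-3 cells (Homo sapiens) for antiproliferative activity, read by MTT assay, with a stated time of 72 h; a higher number here means a weaker inhibitor, a lower number a stronger inhibitor
Compound 1 `COc1ccc(NC(=O)CCc2cccc3c2B(O)OC3)cc1` gives 900 nM
Compound 2 `CC(C)(C)OC(=O)NCc1ccc(NC(=O)CCc2cccc3c2B(O)OC3)cc1` gives 2000 nM

With 2000 nM in hand, compound 2 holds the higher number of the pair, so it is the weaker inhibitor. Compound 3 `CCOC(=O)c1ccc(NC(=O)CCc2cccc3c2B(O)OC3)cc1` has ethoxycarbonyl in place of ((tert-butoxycarbonyl)amino)methyl on an aromatic carbon on the same core. Among the measured compounds shown here, only one measured step bears on this, a 2.2-fold higher number from compound 1 to compound 2 (0.35 log units; beyond the scatter) with ((tert-butoxycarbonyl)amino)methyl in place of methoxy, and it is modest. A similar or smaller step toward a lower number is therefore expected in this assay for this change. The estimated step is a 1.7-fold lower number from compound 2 to compound 3 (0.22 log units; within the scatter) on this single comparison. Compound 3 is expected at about 1200 nM within a range of 500 nM to 3000 nM in this estimate.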

Compound 3, half-maximal inhibitory concentration: > 100000 nM
Compound 3: a limit, no number; the forecaster's own chance of this, stated with the estimate: 3%; middle value at least 83-fold (1.92 log units) away from the limit.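

Compound 3 gives a limit of the assay, not a number: the limit of > 100000 nM in this assay, at which 1 of the 3 values shown sits. In this assay that limit still fixes the size of the change, with an at least 50-fold higher number from compound 2 to compound 3 (1.69 log units; beyond the scatter) and an at least 110-fold higher number from compound 1 to compound 3 (2.04 log units; beyond the scatter). So this position on the aromatic ring tolerated both methoxy and ((tert-butoxycarbonyl)amino)methyl with only a modest shift, yet ethoxycarbonyl here removes any measurable value.

Still open, as far as these compounds go, is whether this loss belongs to the ethyl ester alone or extends to related groups at this place, such as a carboxylic acid or a simple amide.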